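Isopropyl to isobutyl in indole and pyrrole peptide acids

The compounds below may be only part of what the source reports. "The series", "measured", "known", "first", "only" and "open" are said of these compounds alone.

Compound 1 `C=CCONC(=O)Cn1cc(C(=O)N[C@@H](C)C(=O)N[C@H](C(=O)O)C(C)C)c2ccccc21` gives the limit > 128000 nM in a functional assay on RAW264.7 cells (Mus musculus) for inhibition, read by microscopy and resazurin assay, with a stated time of 72 h; a higher number here means a weaker inhibitor, a lower number a stronger inhibitor.
Compound 2 `C=CCONC(=O)Cn1cc(C(=O)N[C@@H](C)C(=O)N[C@@H](CC(C)C)C(=O)O)c2ccccc21` gives the limit > 128000 nM in this assay.
Compound 3 `CC(C)[C@H](NC(=O)[C@H](C)NC(=O)c1ccn(CC(=O)NOCc2ccccc2)c1)C(=O)O` gives the limit > 128000 nM in this assay.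

Among the compounds with values here, every value so far is a limit of the assay and not a number: the limit of > 128000 nM in this assay, at which 3 of the 3 values shown sit. The change isobutyl in place of isopropyl on a saturated chain carbon bound to an amide-type nitrogen and a carbonyl carbon gives a step that the two limits leave unreadable from compound 1 to compound 2. Compound 1 and compound 3 share the same atoms joined differently; the difference between the two cores is not broken down here.

Compound 4 `CC(C)C[C@H](NC(=O)[C@H](C)NC(=O)c1ccn(CC(=O)NOCc2ccccc2)c1)C(=O)O` is not yet measured. It differs from compound 3 by isobutyl in place of isopropyl on a saturated chain carbon bound to an amide-type nitrogen and a carbonyl carbon, the same change as between compound 1 and compound 2. For compound 4 the expected step is a step that the limit leaves unreadable from compound 3 to compound 4. Compound 4 is expected at 200000 nM, between 100000 nM and 600000 nM, most likely again only a limit. This expectation rests on compound 3 giving the limit > 128000 nM. It also rests on the unreadable step that the two limits leave unreadable from compound 1 to compound 2.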

Compound 4, half-maximal inhibitory concentration: > 128000 nM
Compound 4 gave a limit, no number; the forecaster's own chance of this, stated with the estimate: 90%; the middle value lies beyond the limit too.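

No step can be read between compound 3 and compound 4, since both give only limits in this assay: the limit of > 128000 nM in this assay, at which 4 of the 4 values shown sit.

Whether isobutyl in place of isopropyl alters inhibition at all, and how the compounds shown rank against one another, stays open.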